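Replacing groups on the saturated chain carbon: series notes

A few compounds are considered here, and "the series" means these few. Any claim that something is new, unique, unknown or untested is made for them only; others in the source may bear on it.

Compound 1 `O=C(NCc1cc(C(F)(F)F)cc(C(F)(F)F)c1)c1c(CCl)nc2ccccc2c1-c1ccccc1` gives 26 nM in an in vitro assay on UC11MG cells for binding affinity to Substance-P receptor (Homo sapiens), read by radioligand binding; on this read-out higher numbers stand for weaker inhibition and lower numbers for stronger inhibition.
Compound 2 `O=C(NCc1cc(C(F)(F)F)cc(C(F)(F)F)c1)c1c(CBr)nc2ccccc2c1-c1ccccc1` gives 0.01 nM in this assay.
Compound 3 `O=C(NCc1cc(C(F)(F)F)cc(C(F)(F)F)c1)c1c(CN2C(=O)c3ccccc3C2=O)nc2ccccc2c1-c1ccccc1` gives > 1000 nM in this assay.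

For compound 3 the value in this assay is a limit of the assay, not a number (the limit of > 1000 nM in this assay, at which 1 of the 3 values shown sits). Compound 3 therefore stands at the weak end of what has been measured, with no exact position known. The two steps reaching compound 3 are both large: an at least 38-fold higher number from compound 1 to compound 3 (1.58 log units; beyond the scatter) and an at least 100000-fold higher number from compound 2 to compound 3 (5.00 log units; beyond the scatter). Both replace a single halogen on the saturated chain carbon bound to an aromatic carbon with the larger ring-bearing group of compound 3, and both go toward weaker inhibition. The step of a 2600-fold lower number from compound 1 to compound 2 (3.41 log units; beyond the scatter) shows how much the halogen alone can shift the number.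

Compound 4 `CC(C)(C)[Si](C)(C)OCc1nc2ccccc2c(-c2ccccc2)c1C(=O)NCc1cc(C(F)(F)F)cc(C(F)(F)F)c1` differs from compound 3 by a group of 8 heavy atoms (6 carbon, 1 oxygen, 1 silicon; no ring) in place of a group of 11 heavy atoms (8 carbon, 1 nitrogen, 2 oxygen; one five-membered non-aromatic ring with 1 hetero atom, one six-membered aromatic ring of carbon only), on a saturated chain carbon bound to an aromatic carbon. The entering group is still much larger than the halogens of compound 1 and compound 2, so the direction relative to those two is expected to remain toward weaker inhibition, but with no ring it sits between the halogens and the group of compound 3 in size. Since compound 3 is only a limit, the size of the step of an at least 2.5-fold lower number from compound 3 to compound 4 (0.39 log units; beyond the scatter) is estimated with low confidence. Compound 4 is expected to give about 400 nM in this assay, within 40 nM to 4000 nM, with a real chance that only a limit is again reported.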

Compound 4, half-maximal inhibitory concentration: 17 nM
Compound 4: the middle estimate sits 24-fold (1.37 log units) above what was measured; measured number below the stated range.
By their numbers in this assay, from the lowest: compound 2; then compounds 4 and 1 (each within the scatter of the next). At a limit, above all of these: compound 3.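

At this saturated chain carbon bound to an aromatic carbon, heavy-atom count alone no longer orders the results in this assay: the group of 8 heavy atoms (6 carbon, 1 oxygen, 1 silicon; no ring) gives a 1.5-fold lower number from compound 1 to compound 4 (0.18 log units; within the scatter), so it cannot be told apart from the single chlorine atom, while a 1700-fold higher number from compound 2 to compound 4 (3.23 log units; beyond the scatter) keeps the bromine compound apart. Among the two large groups, the change shows an at least 58-fold lower number from compound 3 to compound 4 (1.76 log units; beyond the scatter), so a large group at this place does not by itself go with the weak end of the series. The reading of that step is bounded, as compound 3 carries a limit and not a number: the limit of > 1000 nM in this assay, at which 1 of the 4 values shown sits.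

Iodine, a plain hydroxyl or an amine on the same carbon would test whether the bromine result stands alone among the groups at this place. It also remains open which part of the entering group of compound 4, the oxygen or the silicon-bearing part, goes with its value, as no compound shown carries one without the other.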